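The compounds below may be only part of what the source reports. "The series", "measured", "known", "first", "only" and "open" are said of these compounds alone.

Compound 1 `COc1ccc(C(=O)/C=C/c2cccc(F)c2)c2c1C=CC(C)(C)O2` gives > 10000 nM in a functional assay on HCT-116 cells (Homo sapiens) for antiproliferative activity, read by MTT assay, with a stated time of 24 h (on this read-out lower numbers stand for stronger inhibition and higher numbers for weaker inhibition), a limit of the assay and not a number.
Compound 2 `COc1ccc(C(=O)/C=C/c2ccc(Br)cc2)c2c1C=CC(C)(C)O2` gives > 10000 nM in this assay, likewise a limit of the assay.
Compound 3 `COc1ccc(C(=O)/C=C/c2cccc([N+](=O)[O-])c2)c2c1C=CC(C)(C)O2` gives 8050 nM in this assay.

Compound 1 therefore stands only at a limit, with no measured number of its own. Among the measured steps, the move from compound 1 to compound 2 is a step that the two limits leave unreadable from compound 1 to compound 2, since both sit at the limit of > 10000 nM in this assay, at which 2 of the 3 values shown sit. The move from compound 1 to compound 3 is an at least 1.2-fold lower number from compound 1 to compound 3 (0.09 log units; that floor lies within the scatter), and that from compound 2 to compound 3 is an at least 1.2-fold lower number from compound 2 to compound 3 (0.09 log units; that floor lies within the scatter). The unmeasured compound 4 `COc1ccc(C(=O)/C=C/c2ccc(O)cc2)c2c1C=CC(C)(C)O2` differs from compound 1 by 4-hydroxyphenyl in place of 3-fluorophenyl on a double-bonded chain carbon bound to a double-bonded chain carbon. Within the data shown here, no measured step places a 4-hydroxyphenyl at this place; the one step that exchanges the ring at the same place, from compound 1 to compound 2, is unreadable, and the only readable step, to compound 3, has a floor within the scatter. Hence no step beyond the scatter is expected in this assay in either direction, and compound 4 is expected to sit near compound 1, with a fair chance that the assay again reports only a limit. Compound 4 is accordingly estimated at 10000 nM, between 3000 nM and 30000 nM, which means an expected step of a number no higher from compound 1 to compound 4 (the limit leaves the size open).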

Compound 4, half-maximal inhibitory concentration: > 10000 nM
Compound 4: a limit, no number; the forecaster's own chance of this, stated with the estimate: 65%; the middle value lies on the limit itself.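

With 4-hydroxyphenyl on the double-bonded chain carbon, a ring carrying a hydrogen-bond donor and acceptor, which 3-fluorophenyl lacks, now also ends at a limit of this assay and not at a number, so this change does not bring compound 4 into the measurable range. Among these compounds, the steps from compound 1 and from compound 2 to compound 4 cannot be read, as both ends are limits, and the only readable step is an at least 1.2-fold higher number from compound 3 to compound 4 (0.09 log units; that floor lies within the scatter), so nothing here shows compound 3 to differ from compound 4 by more than the scatter. Across these ring exchanges, the position now reads mostly as a ceiling: the limit of > 10000 nM in this assay, at which 3 of the 4 values shown sit.

On these data alone, the size of any difference among compound 1, compound 2 and compound 4 stays open, since none of the three has a number of its own. Also open, as far as these compounds go, is whether an amine or a carboxylic acid on the aromatic ring, or a longer chain at this place, would give a number clearly below that limit.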